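The compounds below may be only part of what the source reports. "The series", "measured", "known", "first", "only" and "open" are said of these compounds alone.

In a physicochemical assay for solubility, using the shake flask method, measured as kinetic solubility, with a stated time of 20 h, at pH 2 (a lower number here means a less soluble compound, a higher number a more soluble compound), compound 1 `Fc1ccc(Nc2cc3[nH]c(-c4cccc(C(F)(F)F)c4)nc3cn2)nc1` gives < 5000 nM, which is a limit of the assay. Compound 2 `Fc1ccc(-c2nc3cnc(Nc4cc(C(F)(F)F)ccn4)cc3[nH]2)cc1F` gives < 5000 nM, also a limit. Among the measured compounds shown here, compound 3 `FC1(F)CCC(c2nc3cnc(Nc4ccc(C(F)(F)F)cn4)cc3[nH]2)C1` carries the only actual number, 185000 nM, so there is no other number to rank it against. Compound 4 `FC1(F)CC(c2nc3cnc(Nc4ccc(C(F)(F)F)cn4)cc3[nH]2)C1` has 3,3-difluorocyclobutyl in place of the 3,3-difluorocyclopentyl of compound 3 on an aromatic carbon (3,3-difluorocyclobutyl in place of 3,3-difluorocyclopentyl on an aromatic carbon). For the measured compounds named here, no measured step gauges this ring change, so no shift beyond the scatter is expected in this assay, with compound 3 at 185000 nM as the anchor. The expected size of the change is a 1.1-fold higher number from compound 3 to compound 4 (0.03 log units; within the scatter). For compound 4 the estimated value is 200000 nM, with an expected range of 70000 nM to 500000 nM.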

Compound 4, solubility: 181000 nM
Beside the measured number, compound 4's estimate is 1.1-fold (0.04 log units) above it; the range from low to high includes it.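

In this assay, among the compounds shown here, the only step at this position, on an aromatic carbon between two ring nitrogen atoms, is a 1.0-fold lower number from compound 3 to compound 4 (0.01 log units; within the scatter). The four-membered and five-membered difluorinated rings are therefore not separated by this read-out, at least for this pair. Compounds 1 and 2 differ from these two in more than one place and give no step, and their values are limits: the limit of < 5000 nM in this assay, at which 2 of the 4 values shown sit.

Open, going by these compounds, is what an amine or a carboxylic acid on this carbon gives. Also open, on these data alone, is whether plain cyclobutyl, without its two fluorines, matches 3,3-difluorocyclobutyl.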